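The source may hold more compounds than are shown below. What is called first, only, known or untested is meant among the compounds shown, and "the series" means these compounds.

Measured compounds:
- compound 1, `Cc1cccc(NC(=O)C(Cl)Cl)c1`, "not determined" (no result reported) in a functional assay on Bel-7402 cells (Homo sapiens) for antiproliferative activity, read by MTT assay, with a stated time of 72 h; on this read-out lower numbers stand for stronger inhibition and higher numbers for weaker inhibition
- compound 2, `O=C(Nc1cccc(F)c1)C(Cl)Cl`, "not determined" (no result reported) in this assay
- compound 3, `O=C(Nc1cccc(Cl)c1)C(Cl)Cl`, 44500 nM in this assay

Going by the values given here, compound 3 is therefore the only compound of the set with a number, and its half-maximal inhibitory concentration is the sole point of reference; compounds 1 and 2 carry no result at all, so nothing can be compared across them.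

Compound 4, `O=C(Nc1cccc(I)c1)C(Cl)Cl`, is not yet measured. It differs from compound 3 by iodo in place of chloro on an aromatic carbon. Among the compounds with values here, with no measured pair of this kind at hand, the change is expected to move the number little, within the scatter or by a modest step toward stronger inhibition. Compound 4 is accordingly estimated at 30000 nM, with a range from 10000 nM to 90000 nM, which means an expected step of a 1.5-fold lower number from compound 3 to compound 4 (0.17 log units; within the scatter).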

Compound 4, half-maximal inhibitory concentration: 5390 nM
For compound 4 the middle estimate is 5.6-fold (0.75 log units) above the measured one; measured number below the stated range.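

Replacing chloro with iodo on this aromatic carbon gives an 8.3-fold lower number from compound 3 to compound 4 (0.92 log units; beyond the scatter) in this assay. This first readable step shows that the number at this position can depend on which halogen is present, something a single value could not show. Nothing available explains the step.

Steps involving compound 1 and compound 2 cannot be read, so it remains open whether the number follows a trend across the halogens. As far as these compounds go, how an amine or a methoxy group at this position would compare also remains open.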